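The compounds below may be only part of what the source reports. "The series", "measured", "known", "first", "only" and "open" are said of these compounds alone.

In a functional assay on RAW264.7 cells (Mus musculus) for inhibition (on this read-out lower numbers stand for stronger inhibition and higher numbers for weaker inhibition), compound 1 `CCOC(=O)C1=CCCCC1S(=O)(=O)Nc1cccc(F)c1` gives 150 nM, compound 2 `CCOC(=O)C1=CCCCC1S(=O)(=O)Nc1ccc(F)cc1` gives 110 nM, and compound 3 `CCOC(=O)C1=CCCCC1S(=O)(=O)Nc1ccccc1Cl` gives 12 nM, the lowest number of the three. Compound 4 `CCOC(=O)C1=CCCCC1S(=O)(=O)Nc1ccc(Cl)cc1` carries 4-chlorophenyl in place of 2-chlorophenyl on a sulfonamide nitrogen. The closest guide is a 9.2-fold lower number from compound 2 to compound 3 (0.96 log units; beyond the scatter), which runs the opposite way and also changes the halogen. A similar gap appears in a 13-fold lower number from compound 1 to compound 3 (1.10 log units; beyond the scatter), whereas a 1.4-fold lower number from compound 1 to compound 2 (0.13 log units; within the scatter) stays within the scatter. Among the measured compounds shown here, no measured pair swaps the halogen alone, so the guide is indirect. A sizeable rise in this assay is therefore expected, estimated as an 8.3-fold higher number from compound 3 to compound 4 (0.92 log units; beyond the scatter). Compound 4 is expected at 100 nM, with an estimated range of 40 nM to 250 nM.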

Compound 4, half-maximal inhibitory concentration: 400 nM
Beside the measured number, compound 4's estimate is 4.0-fold (0.60 log units) below it; the whole stated range lies below it.
By their numbers in this assay, from the lowest: compound 3; then compounds 2 and 1 (each within the scatter of the next); then compound 4.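

In this assay, 4-chlorophenyl in place of 2-chlorophenyl on a sulfonamide nitrogen gives a 33-fold higher number from compound 3 to compound 4 (1.52 log units; beyond the scatter), so with the halogen unchanged, its location on the phenyl ring alone makes a large difference. Chloro in place of fluoro on an aromatic carbon gives a 3.6-fold higher number from compound 2 to compound 4 (0.56 log units; beyond the scatter), which shows that chloro does not lower the number in every setting. The 4-chlorophenyl group also falls behind 3-fluorophenyl, with a 2.7-fold higher number from compound 1 to compound 4 (0.43 log units; beyond the scatter).

Nothing available accounts for the size of these steps. Going by these compounds, whether 2-fluorophenyl, 2-methylphenyl or 2-methoxyphenyl would keep a number as low as that of compound 3 remains open.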